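From 3-methoxyphenyl to 2-bromophenyl on the carbonyl

The source may hold more compounds than are shown below. What is called first, only, known or untested is meant among the compounds shown, and "the series" means these compounds.

- compound 1 `Cn1cc(-c2nc3ccccc3n2C(=O)c2ccccc2Br)c2ccccc21`: 68200 nM
- compound 2 `COc1ccc2c(c1)c(-c1nc3ccccc3n1C(=O)c1ccccc1Br)cn2C`: 54200 nM
- compound 3 `COc1cccc(C(=O)n2c(-c3cn(C)c4ccc(Br)cc34)nc3ccccc32)c1`: 17800 nM

In a functional assay on HepG2 cells (Homo sapiens) for inhibition, read by MTT assay, with a stated time of 24 h (on this read-out lower numbers stand for stronger inhibition of growth and higher numbers for weaker inhibition of growth), compound 3 has the lowest of the three numbers, and its gaps to compound 1 and compound 2 lie beyond the usual scatter. The unmeasured compound 4 `Cn1cc(-c2nc3ccccc3n2C(=O)c2ccccc2Br)c2cc(Br)ccc21` keeps the core of compound 3 and changes one group: 2-bromophenyl in place of 3-methoxyphenyl on a carbonyl carbon. Compound 1 and compound 2 carry the same 2-bromophenyl on their carbonyl carbon. Among the measured compounds shown here, the only measured step is a 1.3-fold lower number from compound 1 to compound 2 (0.10 log units; within the scatter). For the measured compounds named here, it lies within the scatter and concerns the core rather than this group, so no measured pair isolates the swap itself. The numbers for compound 1 at 68200 nM and compound 2 at 54200 nM both sit above that of compound 3 at 17800 nM, so a moderately higher number, meaning weaker inhibition of growth, is expected in this assay. The expected change is a 2.2-fold higher number from compound 3 to compound 4 (0.35 log units; beyond the scatter), and this remains an estimate. For compound 4 the estimated value is 40000 nM, with an expected range from 15000 nM to 90000 nM.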

Compound 4, concentration for 50% growth inhibition: 72100 nM
The estimate for compound 4 lay 1.8-fold (0.26 log units) below the measured number, and the stated range covers the measured number.
By their numbers in this assay, from the lowest: compound 3; then compounds 2, 1 and 4 (each within the scatter of the next).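

With the core held fixed, the swap on the carbonyl carbon now has a direct measurement in this assay: 2-bromophenyl in place of 3-methoxyphenyl gives a 4.1-fold higher number from compound 3 to compound 4 (0.61 log units; beyond the scatter) and so shows that this group matters in this series. With 2-bromophenyl on the carbonyl, changing the group on the aromatic carbon of the core gives a 1.3-fold higher number from compound 2 to compound 4 (0.12 log units; within the scatter) for bromo in place of methoxy and a 1.1-fold higher number from compound 1 to compound 4 (0.02 log units; within the scatter) for bromo in place of hydrogen, so compounds 1, 2 and 4 cannot be told apart. No measured evidence here explains the difference between compound 3 and compound 4.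

The compounds shown leave open whether 3-methoxyphenyl would give a similar step on the cores of compound 1 or compound 2. They also leave open how an aminophenyl or a carboxyphenyl group would behave on the same carbonyl carbon.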